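Bromo to Cyano on the Benzyl Ring: Cytotoxicity Outlook

The source may report more compounds than this note shows. Statements on the series, on what has been measured and on what is new or still open speak of the compounds shown alone.

Of the compounds shown here, three have been measured so far. Compound 1 `COC(=O)c1ccc(NCc2cncn2Cc2cccc(Br)c2)cc1-c1ccccc1` gives > 10000 nM in a toxicity assay on NIH3T3 cells (Mus musculus) for cytotoxicity, read by resazurin assay; a lower number here means that less compound is needed, a higher number that more compound is needed for the effect. Compound 2 `N#Cc1ccc(NCc2cncn2Cc2ccc(-c3ccccc3)cc2)cc1-c1ccccc1` gives > 1000 nM in this assay. Compound 3 `O=C(c1ccc(NCc2cncn2Cc2ccc(-c3ccccc3)cc2)cc1-c1ccccc1)N1CCCCC1` gives > 1000 nM in this assay.

Each of these values is a limit of the assay rather than a number. Compound 1 sits at the upper limit of the dilution series, so its true value is not known beyond that. Among the measured compounds shown here, the only step between measured compounds that differ in one place is a step that the two limits leave unreadable from compound 2 to compound 3, and its size cannot be read because both ends are limits.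

Compound 4 `COC(=O)c1ccc(NCc2cncn2Cc2cccc(C#N)c2)cc1-c1ccccc1` differs from compound 1 by cyano in place of bromo on an aromatic carbon. For the measured compounds named here, no measured pair bears on this change directly. What is known is that the limit of > 1000 nM in this assay, at which 2 of the 3 values shown sit, and the limit of > 10000 nM in this assay, at which 1 of the 3 values shown sits: none of the three compounds shows measurable toxicity within the tested range.

On that basis compound 4 is expected to behave like compound 1 and give 15000 nM in this assay, ranging from 5000 nM to 50000 nM, most likely again as a limit. The step that the limit leaves unreadable from compound 1 to compound 4 is therefore estimated to lie within the scatter.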

Compound 4, half-maximal effective concentration: > 10000 nM
Compound 4: no number, only a limit; the forecaster's own chance of this, stated with the estimate: 80%; the middle value lies beyond the limit too.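

In this assay compound 4 gives > 10000 nM, a limit and not a number. Compound 1 gives > 10000 nM, also a limit. Among the compounds shown here, no step between compound 1 and compound 4 can therefore be read. The compounds shown leave open what concentration, if any, would make either compound toxic to these cells.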